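The source may report more compounds than this note shows. Statements on the series, on what has been measured and on what is new or still open speak of the compounds shown alone.

Measured compounds:
Compound 1 `CCN(CC)S(=O)(=O)c1ccc(S(=O)(=O)N2CCC[C@@H](C(=O)N3CCC(O)CC3)C2)cc1` — in a functional assay on MIA PaCa-2 cells (Homo sapiens) for inhibition, read by MTT assay, with a stated time of 3 days (on this read-out lower numbers stand for stronger inhibition and higher numbers for weaker inhibition), compound 1 gives > 10000 nM, which is a limit of the assay and not a number.
Compound 2 `CC(C)S(=O)(=O)c1ccc(S(=O)(=O)N2CCC[C@@H](C(=O)N3CCC(F)(F)CC3)C2)cc1` — in this assay compound 2 gives > 3000 nM, likewise only a limit.

Among the compounds with values here, compound 1 therefore has no numeric value to stand on; it sits at its limit (the limit of > 10000 nM in this assay, at which 1 of the 2 values shown sits), and the one further value shown is itself a limit (the limit of > 3000 nM in this assay, at which 1 of the 2 values shown sits), so the two cannot be ordered against each other.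

Compound 3 `CCN(CC)S(=O)(=O)c1ccc(S(=O)(=O)N2CCC[C@@H](C(=O)N[C@H]3CCOC3)C2)cc1` differs from compound 1 by (oxolan-3-yl)amino in place of 4-hydroxypiperidin-1-yl on a carbonyl carbon. Within the data shown here, no measured pair in this set carries that change, so its size cannot be read from the data. With the measured value being a limit (the limit of > 10000 nM in this assay, at which 1 of the 2 values shown sits), the expected step that the limit leaves unreadable from compound 1 to compound 3 is none beyond the scatter. Compound 3 is estimated to give 15000 nM in this assay, in a range from 3000 nM to 80000 nM, most probably reported again only as a limit.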

Compound 3, half-maximal inhibitory concentration: > 10000 nM
Compound 3 gave a limit, no number (the forecaster's own chance of this, stated with the estimate: 75%); the middle value lies beyond the limit too.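

Compound 1 and compound 3 both rest only on a limit, so no step can be read between them: the limit of > 10000 nM in this assay, at which 2 of the 3 values shown sit.

Left open is what numeric value any compound shown would give in this assay, and whether (oxolan-3-yl)amino in place of 4-hydroxypiperidin-1-yl changes it at all.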